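From compound 2 to compound 3: one ring swapped

This account rests on a few compounds, and the source may have more. Where it says the series, first, only, none or still open, it means among the compounds named here.

Among the measured compounds shown here, in a functional assay on MV4-11 cells (Homo sapiens) for antiproliferative activity, read by resazurin assay, with a stated time of 72 h (on this read-out lower numbers stand for stronger inhibition of growth and higher numbers for weaker inhibition of growth), compound 1 (`CC(=O)N1CCN(c2ccc(Nc3ncc(C#N)c(-c4cn(C)c5ccccc45)n3)cc2)CC1`) gives 30 nM as the lower of the two numbers so far. Compound 2 (`CC(=O)N1CCN(c2ccc(Nc3nccc(-c4cn(C)c5ncccc45)n3)cc2)CC1`) gives 74 nM as the higher number, and its gap to compound 1 lies beyond the usual scatter.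

Compound 3 (`CC(=O)N1CCN(c2ccc(Nc3nccc(-c4cn(C)c5ccccc45)n3)cc2)CC1`) has no number yet. It differs from compound 2 by one change (a group of 10 heavy atoms (9 carbon, 1 nitrogen; one five-membered aromatic ring with 1 hetero atom, one six-membered aromatic ring of carbon only) in place of a group of 10 heavy atoms (8 carbon, 2 nitrogen; one five-membered aromatic ring with 1 hetero atom, one six-membered aromatic ring with 1 hetero atom), on an aromatic carbon) on an aromatic carbon of a six-membered aromatic ring with 2 nitrogen. The entering group is 1-methyl-1H-indol-3-yl, which brings a six-membered aromatic ring of carbon only in place of a six-membered aromatic ring with 1 hetero atom.

For the measured compounds named here, no measured pair shows this change alone, so the expectation is uncertain. In this assay a small step toward a lower number is expected, not beyond the scatter (a 1.3-fold lower number from compound 2 to compound 3 (0.13 log units; within the scatter)) and resting on the structural change only. Compound 3 is estimated at 55 nM with an expected range from 20 nM to 150 nM in this read-out.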

Compound 3, concentration for 50% growth inhibition: 252 nM
Estimate against measurement, compound 3: 4.6-fold (0.66 log units) below, outside the stated range (above it).
By their numbers in this assay, from the lowest: compound 1; then compound 2; then compound 3.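

In this assay the entering 1-methyl-1H-indol-3-yl gives a 3.4-fold higher number from compound 2 to compound 3 (0.53 log units; beyond the scatter) and so, on this aromatic carbon, the group with the extra ring nitrogen goes with the lower number in this pair. Compound 3 also serves as the single-change partner of compound 1: hydrogen in place of cyano gives an 8.4-fold higher number from compound 1 to compound 3 (0.92 log units; beyond the scatter) and so each of the two changes, read on its own from compound 3, goes with a lower number beyond the scatter. Nothing measured here gives a reason for either step.

Going by these compounds, whether the cyano group and the extra ring nitrogen add up when carried in one compound stays open. Also open, on these data alone, is how a chlorine, a methyl group or an amine would compare with cyano on the core of compound 3.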